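This account rests on a few compounds, and the source may have more. Where it says the series, first, only, none or still open, it means among the compounds named here.

Compound 3 `Cc1cccc(-c2sc(N)c(C(=O)c3ccc(Cl)cc3)c2CC(C)(C)C)c1` gives 1% in an assay on CHO cells for displacement of a labelled ligand from adenosine receptor A3 (Homo sapiens), read by scintillation counting, tested at 10 uM (a higher number here means more inhibition at the concentration tested (going by the name of the read-out), a lower number less inhibition), and stands level with compound 1 `CC(C)(C)Cc1c(-c2cccnc2)sc(N)c1C(=O)c1ccc(Cl)cc1` at 1% and with compound 2 `COc1ccccc1-c1sc(N)c(C(=O)c2ccc(Cl)cc2)c1CC(C)(C)C` at 1%. Each replacement of the aryl group on the aromatic carbon has so far left this assay flat: no change at the digits printed from compound 1 to compound 2 (within the scatter), no change at the digits printed from compound 1 to compound 3 (within the scatter), no change at the digits printed from compound 2 to compound 3 (within the scatter). The next step leads to compound 4 `CC(C)(C)Cc1c(-c2ccsc2)sc(N)c1C(=O)c1ccc(Cl)cc1`, where the change is thiophen-3-yl in place of 3-methylphenyl on an aromatic carbon. The three measured steps, all within the scatter, are the only ones that bear on this aryl position; every aryl tried so far lands at the same low level of inhibition. In this assay, compound 4 is therefore expected to show a number 1 percentage points higher from compound 3 to compound 4 (within the scatter), with an estimated value of 2% and a range from -6% to 12%.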

Compound 4, a percentage reported as inhibition, at one concentration (the size of the read-out at that concentration, not a potency): 4%
Compound 4: the middle estimate sits 2 percentage points below what was measured; measured number inside the range.
By their numbers in this assay, from the lowest: compounds 1, 2, 3 and 4 (each within the scatter of the next).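

In this assay, thiophen-3-yl, a five-membered aromatic ring with a ring sulfur, reads the same as the six-membered aryl groups within the scatter (a number 3 percentage points higher from compound 3 to compound 4 (within the scatter)), (a number 3 percentage points higher from compound 2 to compound 4 (within the scatter)), (a number 3 percentage points higher from compound 1 to compound 4 (within the scatter)). The flat reading at this position therefore extends across a change of ring size and to a sulfur-containing ring. No data at hand give a reason for this flatness.

As far as these compounds go, whether a non-aryl group here, such as an aminomethyl group, a carboxylic acid or a longer alkyl chain, would shift the number stays open. The neopentyl and (4-chlorophenyl)carbonyl groups stay constant throughout, so their contribution cannot be read.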